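The source may report more compounds than this note shows. Statements on the series, on what has been measured and on what is new or still open speak of the compounds shown alone.

Working notes on the series

Compound 1 `OC1CCN(c2ccc(-c3ccccc3F)nn2)CC1` and compound 3 `Cc1ccccc1-c1ccc(N2CCC(O)CC2)nn1` share a core, and in a functional assay on the whole organism with Mus musculus as the target, in the maximal electroshock model (on this read-out lower numbers stand for an effect already at smaller amounts and higher numbers for an effect only at larger amounts of compound), compound 1 gives 115 mg/kg while compound 3 gives 30 mg/kg; the step is a 3.8-fold lower number from compound 1 to compound 3 (0.58 log units; beyond the scatter), and the change is methyl in place of fluoro on an aromatic carbon. Compound 2 `OC1CCN(c2ccc(-c3ccc(F)cc3)nn2)CC1` gives 48 mg/kg in this assay; the difference between its core and that of compound 1 is not broken down here. Compound 4 `Cc1ccc(-c2ccc(N3CCC(O)CC3)nn2)cc1` carries the change methyl in place of fluoro on an aromatic carbon relative to compound 2. This is the same kind of change as that from compound 1 to compound 3, but the place is not the same: there the group sits ortho to a large group, here para to a large group. Among the compounds with values here, a step of similar direction but uncertain size is therefore expected, a 1.9-fold lower number from compound 2 to compound 4 (0.28 log units; within the scatter), resting on the one observed step of a 3.8-fold lower number from compound 1 to compound 3 (0.58 log units; beyond the scatter). For compound 4 the expected value in this assay is 25 mg/kg, between 12 mg/kg and 55 mg/kg.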

Compound 4, dose for half-maximal effect: 73 mg/kg
The estimate for compound 4 lay 2.9-fold (0.47 log units) below the measured number, outside the stated range (above it).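

In this assay methyl in place of fluoro gives a 1.5-fold higher number from compound 2 to compound 4 (0.18 log units; within the scatter) and so does not repeat the earlier step. The change does not carry over as a fixed increment from one core to the other: the same change on two cores in this assay, a 3.8-fold lower number (0.58 log units; beyond the scatter) from compound 1 to compound 3 and a 1.5-fold higher number (0.18 log units; within the scatter) from compound 2 to compound 4, 5.8-fold (0.77 log units) apart, beyond the scatter of two such steps. Within the data shown here, what this does not show is whether the core or the place is responsible, since the place of the change also differs between the two pairs and each place is represented by only one pair.

Left open is how a chloro or methoxy group at either place would read in this assay and whether a third core would follow either step.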